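A few compounds are considered here, and "the series" means these few. Any claim that something is new, unique, unknown or untested is made for them only; others in the source may bear on it.

In an assay on Sf9 cells for inhibition of mitogen-activated protein kinase kinase kinase 14 variant S549D (Homo sapiens), with a stated time of 30 min, in the presence of a further agent that is not named here (on this read-out lower numbers stand for stronger inhibition and higher numbers for weaker inhibition), compound 2 `C#Cc1cc(C#Cc2ccc3ncn(-c4ccnc(N)n4)c3c2)ccn1` gives 31600 nM, the higher of the two numbers measured here. Its neighbour compound 1 `C#Cc1cccc(C#Cc2ccc3ncn(-c4ccnc(N)n4)c3c2)n1` gives 3160 nM in this assay, and the step of a 10-fold higher number from compound 1 to compound 2 (1.00 log units; beyond the scatter) shows that moving the nitrogen within the ring attached to the triple-bonded carbon already shifted the read-out. Compound 3 `C#Cc1cncc(C#Cc2ccc3ncn(-c4ccnc(N)n4)c3c2)c1` differs from compound 2 by a group of 8 heavy atoms (7 carbon, 1 nitrogen; one six-membered aromatic ring with 1 hetero atom) in place of a group of 8 heavy atoms (7 carbon, 1 nitrogen; one six-membered aromatic ring with 1 hetero atom), on a triple-bonded carbon; the two have the same atoms, joined differently. For the measured compounds named here, only that single step bears on the change, and it was modest but beyond the scatter, so a shift of similar size in either direction is plausible, with no way to tell from these two compounds alone which way it will go. For compound 3 the expected value in this assay is 10000 nM, between 2000 nM and 50000 nM, which would amount to a 3.2-fold lower number from compound 2 to compound 3 (0.50 log units; beyond the scatter).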

Compound 3, half-maximal inhibitory concentration: 63100 nM
Compound 3: middle estimate off by 6.3-fold (0.80 log units), on the low side; measured number outside the range, above it.
By their numbers in this assay, from the lowest: compound 1; then compounds 2 and 3 (each within the scatter of the next).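

Three arrangements of the same atoms have now been seen in the group on the triple-bonded carbon, and in this assay they do not spread evenly. With a 2.0-fold higher number from compound 2 to compound 3 (0.30 log units; within the scatter) the two cannot be told apart, whereas with a 20-fold higher number from compound 1 to compound 3 (1.30 log units; beyond the scatter) compound 1 stands clear as the strongest inhibitor of the three. Nothing measured here explains why that one arrangement differs from the other two.

From the compounds shown here alone, it remains open whether a phenyl ring, with no nitrogen in it, would sit with compound 1 or with the other two. Going by these compounds, it is also open whether adding an amine or a carboxylic acid to the ring of compound 1 would lower its number further or lose what that arrangement has.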